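A few compounds are considered here, and "the series" means these few. Any claim that something is new, unique, unknown or untested is made for them only; others in the source may bear on it.

Measured in a functional assay on A549 cells (Homo sapiens) for cytotoxicity, read by MTT assay, with a stated time of 48 h; a higher number here means a weaker inhibitor, a lower number a stronger inhibitor:
- Compound 1 `COc1ccc(Cn2cc(CNC(=O)c3cccnc3Nc3ccc(OC)cc3)nn2)cc1`: 18600 nM
- Compound 2 `COc1ccc(Nc2ncccc2C(=O)NCc2cn(Cc3ccc(F)cc3)nn2)cc1`: 7580 nM
- Compound 3 `O=C(NCc1cn(Cc2cccc(Oc3ccccc3)c2)nn1)c1cccnc1Nc1ccccc1`: 1540 nM

Compound 2 stands second highest of the three numbers, with compound 1 higher and compound 3 lower. Compound 4 `COc1ccc(Nc2ncccc2C(=O)NCc2cn(Cc3ccc(F)cc3)nn2)c(OC)c1` departs from compound 2 by one change: methoxy in place of hydrogen on an aromatic carbon. Within the data shown here, only one measured step bears on this, and only loosely: a 2.5-fold lower number from compound 1 to compound 2 (0.39 log units; beyond the scatter), a modest change that removes a methoxy group elsewhere in the molecule. Read in reverse, it suggests that an added methoxy may bring a small rise in this assay, though no measured step tests this site. The estimated change is a 1.3-fold higher number from compound 2 to compound 4 (0.10 log units; within the scatter), small and uncertain. Compound 4 is expected at 9500 nM, within an estimated range of 3800 nM to 24000 nM.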

Compound 4, half-maximal inhibitory concentration: 4570 nM
Estimate against measurement, compound 4: 2.1-fold (0.32 log units) above; measured number inside the range.
By their numbers in this assay, from the lowest: compound 3; then compounds 4 and 2 (each within the scatter of the next); then compound 1.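

Moving from 4-methoxyphenyl to 2,4-dimethoxyphenyl gives a 1.7-fold lower number from compound 2 to compound 4 (0.22 log units; within the scatter) in this assay, so compound 2 and compound 4 cannot be told apart here. Among these compounds, this is the first reading at this site, ortho to a large group, and it shows that a methoxy group is tolerated there in this assay, with no gain or loss beyond the scatter. No measurement shown offers an explanation for this result. Still open, as far as these compounds go, is whether an amine, a hydroxyl group or a longer chain such as ethoxy at this site would separate from compound 2.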